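The source may report more compounds than this note shows. Statements on the series, on what has been measured and on what is new or still open speak of the compounds shown alone.

Measured compounds:
Compound 1, `COC(=O)C1=C(c2ccc(-c3ccccc3)cc2)C2CCC1C2`, gives 603000 nM.
Compound 2, `COC(=O)C1=C(c2ccc(Cl)c(Cl)c2)C2CCC1C2`, gives 6760 nM.
Compound 3, `COC(=O)C1=C(c2cccc(Cl)c2)C2CCC1C2`, gives 105000 nM.

The read-out throughout is an in vitro assay on COS-1 cells for inhibition of sodium-dependent dopamine transporter (Homo sapiens); a higher number here means a weaker inhibitor, a lower number a stronger inhibitor. Compound 3 stands second highest of the three numbers: compound 1 sits well above it, while compound 2 sits far below it, as the step of a 16-fold higher number from compound 2 to compound 3 (1.19 log units; beyond the scatter) shows. That step removed a chloro group from the ring that carries the remaining chloro, and the number rose sharply.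

Compound 4, `COC(=O)C1=C(c2cccc(Cl)c2Cl)C2CCC1C2`, is not yet measured. It differs from compound 3 by chloro in place of hydrogen on an aromatic carbon. Within the data shown here, the only measured step that bears on this change is the one from compound 2 to compound 3, which is large, so adding a chloro group ortho to the existing chloro is expected to move the number down by a sizable step, though the new position is not the same as in compound 2, which leaves the size uncertain. Compound 4 is therefore expected to give 20000 nM, within the range 5000 nM to 80000 nM, a step of a 5.3-fold lower number from compound 3 to compound 4 (0.72 log units; beyond the scatter).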

Compound 4, inhibition constant: 14800 nM
For compound 4 the middle estimate is 1.4-fold (0.13 log units) above the measured one, within the range that was stated.
By their numbers in this assay, from the lowest: compound 2; then compound 4; then compound 3; then compound 1.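

In this assay, chloro in place of hydrogen on this aromatic carbon, ortho to a chloro group, makes the compound a stronger inhibitor, with a 7.1-fold lower number from compound 3 to compound 4 (0.85 log units; beyond the scatter). The earlier step, a 16-fold higher number from compound 2 to compound 3 (1.19 log units; beyond the scatter), concerned a different aromatic carbon of the same ring, so the new result shows that a lower number with an added chloro is not confined to that one place. Nothing here measures what lies behind the drop in the number at this position, so the reason for it stays unknown.

Going by these compounds, whether fluoro, methyl or methoxy on this same aromatic carbon would also lower the number, as chloro does, remains open. The compounds shown also leave open how an amine or a carboxylic acid would fare there.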